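Shifting a hydroxyl group around the shared core

The source may report more compounds than this note shows. Statements on the series, on what has been measured and on what is new or still open speak of the compounds shown alone.

Compound 3 `Oc1ccc(-c2cc(-c3ccc(OC(F)(F)F)cc3)cc(-c3ccccc3O)n2)cc1` carries a 2-hydroxyphenyl group, a 4-hydroxyphenyl group and a trifluoromethoxyphenyl group on the shared core. In a functional assay on T47D cells (Homo sapiens) for inhibition (a higher number here means a weaker inhibitor, a lower number a stronger inhibitor), compound 3 reaches only the limit > 50000 nM, so no number for it is known. Compound 2 `Oc1cccc(-c2cc(-c3ccc(OC(F)(F)F)cc3)cc(-c3ccccc3O)n2)c1` carries a 3-hydroxyphenyl group instead, and in this assay compound 2 gives 7710 nM. The step of an at least 6.4-fold higher number from compound 2 to compound 3 (0.81 log units; beyond the scatter) is bounded by the limit of > 50000 nM in this assay, at which 2 of the 3 values shown sit. Compound 1 `Oc1ccc(-c2cc(-c3ccc(C(F)(F)F)cc3)cc(-c3ccc(O)cc3)n2)cc1` carries two 4-hydroxyphenyl groups and a trifluoromethylphenyl group. In this assay compound 1 also sits at the limit > 50000 nM.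

Compound 4 `Oc1ccc(-c2cc(-c3ccc(OC(F)(F)F)cc3)cc(-c3ccc(O)cc3)n2)cc1` has not been measured. It differs from compound 3 in 4-hydroxyphenyl in place of 2-hydroxyphenyl on an aromatic carbon, which leaves a compound that, like compound 1, carries two 4-hydroxyphenyl groups. Going by the values given here, the only measured step that moves a hydroxyl group, an at least 6.4-fold higher number from compound 2 to compound 3 (0.81 log units; beyond the scatter), ran toward weaker inhibition. Compound 1 is expected to be the closest guide, since compound 1 gives only the limit > 50000 nM. Compound 4 is therefore expected to remain at the limit, with an estimated step that the limit leaves unreadable from compound 3 to compound 4 that does not stand out from the scatter. The estimate for compound 4 is 60000 nM, within 20000 nM to 200000 nM.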

Compound 4, half-maximal inhibitory concentration: 5150 nM
Estimate against measurement, compound 4: 12-fold (1.07 log units) above, outside the stated range (below it).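

Going by these compounds alone, at the place next to the ring nitrogen, 4-hydroxyphenyl in place of 2-hydroxyphenyl turns a compound stuck at the assay limit into one with a readable value in this assay, with an at least 9.7-fold lower number from compound 3 to compound 4 (0.98 log units; beyond the scatter); moving a hydroxyl group can therefore strengthen inhibition as well as weaken it, whereas the only earlier such step, an at least 6.4-fold higher number from compound 2 to compound 3 (0.81 log units; beyond the scatter), ran toward weaker inhibition. The second new step, an at least 9.7-fold lower number from compound 1 to compound 4 (0.98 log units; beyond the scatter), shows that with two 4-hydroxyphenyl groups on the core, trifluoromethoxy in place of trifluoromethyl separates a readable value from the limit. The true size of both new steps stays unknown, because each starts from a compound that reaches only the limit and so has no exact value: the limit of > 50000 nM in this assay, at which 2 of the 4 values shown sit.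

The compounds shown leave open whether a different group at the place next to the ring nitrogen, such as an amine or a carboxylic acid, would keep this inhibition or lose it. They also leave open how a longer chain, such as ethoxy, would behave in place of trifluoromethoxy.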